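Methyl for fluoro on a cytotoxicity core

This account rests on a few compounds, and the source may have more. Where it says the series, first, only, none or still open, it means among the compounds named here.

Three compounds were run in an ADME assay on Vero cells (Chlorocebus sabaeus) for cytotoxicity, read by MTT assay, with a stated time of 72 h; on this read-out lower numbers stand for stronger inhibition and higher numbers for weaker inhibition. Compound 1 `COc1ccc2c(c1)[n+]([O-])c(C#N)c(-c1ccccc1)[n+]2[O-]` gave "nd(insoluble)" (no result reported) in this assay, so no number is recorded for it. Compound 2 `COc1ccc2c(c1)[n+]([O-])c(C#N)c(-c1ccc(F)cc1)[n+]2[O-]` gave 95.1 ug/mL in this assay, the higher of the two numbers recorded. Compound 3 `Cc1ccc(-c2c(C#N)[n+]([O-])c3ccccc3[n+]2[O-])cc1`, which carries a different core, gave 0.68 ug/mL in this assay, a gap from compound 2 that lies well beyond the usual scatter.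

The step now followed leads from compound 2 to compound 4 `COc1ccc2c(c1)[n+]([O-])c(C#N)c(-c1ccc(C)cc1)[n+]2[O-]`, which shares the core of compound 2 and differs from it only by methyl in place of fluoro on an aromatic carbon. Within the data shown here, no measured pair shows this same change on a shared core, so the size of the step rests on expectation alone. Compound 2 at 95.1 ug/mL sits far from compound 3 at 0.68 ug/mL, and compound 4 carries the methyl group found in compound 3 on the core of compound 2; the expected step of a 3.8-fold lower number from compound 2 to compound 4 (0.58 log units; beyond the scatter) in this assay is therefore toward a lower number, beyond the scatter, though with wide uncertainty. Compound 4 is expected to give about 25 ug/mL in this assay, in a range from 3 ug/mL to 100 ug/mL.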

Compound 4, half-maximal inhibitory concentration: 3.8 ug/mL
For compound 4 the middle estimate is 6.6-fold (0.82 log units) above the measured one; low and high end bracket the measured number.
By their numbers in this assay, from the lowest: compound 3; then compound 4; then compound 2.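

In this assay, among these compounds, the change from 4-fluorophenyl to 4-methylphenyl on the shared core gives the first measured step at this position, para to a large group: a 25-fold lower number from compound 2 to compound 4 (1.40 log units; beyond the scatter). Thus, a swap of one heavy atom for another at this aromatic carbon is enough to move the number by a large step. With the 4-methylphenyl group held constant, methoxy in place of hydrogen on an aromatic carbon gives a 5.6-fold higher number from compound 3 to compound 4 (0.75 log units; beyond the scatter), a smaller step in the opposite direction, and the compounds shown offer no measurement that accounts for either step.

Compound 1 gives "nd(insoluble)" (no result reported), so hydrogen at this position has no number to set against fluoro or methyl on the shared core. With only these two numbered groups at this position, the compounds shown leave open where chloro, an amine or a longer chain would fall, and whether fluoro in place of methyl would bring a similar step on the core of compound 3.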